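From Phenyl to Furan-2-yl: Expecting Compound 4

The compounds below may be only part of what the source reports. "The series", "measured", "known", "first", "only" and "open" are said of these compounds alone.

Of the compounds shown here, three have been measured in an assay on isolated protein for inhibition of DNA topoisomerase 1 (Homo sapiens), with a stated time of 30 min, tested at 100 uM; on this read-out lower numbers stand for a weaker effect and higher numbers for a stronger effect at the one concentration tested. Compound 1 `Oc1ccccc1-c1cc(-c2ccccc2)cc(-c2ccccc2O)n1` gives 0%. Compound 2 `Oc1cccc(-c2cc(-c3ccccc3)cc(-c3ccncc3)n2)c1` gives 70.4%. Compound 3 `Oc1cccc(-c2cc(-c3ccccc3)nc(-c3ccccc3)c2)c1` gives 11.5%. On these numbers compound 3 stands second highest of the three: its nearest neighbour is compound 1, whose value lies lower by a margin beyond the usual scatter, while compound 2 lies furthest away, higher by a margin well beyond it. No two of these compounds differ in only one place, so no single step between measured compounds can be drawn on; the three values can only be set side by side.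

Compound 4 `Oc1cccc(-c2cc(-c3ccccc3)nc(-c3ccco3)c2)c1` has not yet been measured. It differs from compound 3 in one place: furan-2-yl in place of phenyl on an aromatic carbon. For the measured compounds named here, no measured pair shows what this kind of change does, so the expectation rests on compound 3 alone. In this assay the expected step is a number 3.5 percentage points higher from compound 3 to compound 4 (within the scatter), small and without a clear direction beyond the scatter. Compound 4 is therefore estimated to give 15%, with a likely range from 0% to 45%.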

Compound 4, a percentage reported as inhibition, at one concentration (the size of the read-out at that concentration, not a potency): 48.8%
For compound 4 the middle estimate is 33.8 percentage points below the measured one; measured number above the stated range.
By their numbers in this assay, from the lowest: compound 1; then compound 3; then compound 4; then compound 2.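

In this assay, for the compounds shown here, replacing phenyl with furan-2-yl on the aromatic carbon next to the ring nitrogen gives a number 37.3 percentage points higher from compound 3 to compound 4 (beyond the scatter) and provides the only single-place comparison in this set. Going by these compounds alone, it shows that the read-out is sensitive to the group at this position, which the earlier compounds could not show because no two of them differed in only one place. The change itself looks small on paper, a six-membered carbon ring giving way to a five-membered ring with one oxygen and one hydrogen-bond acceptor, yet the step is large, and no measurement at hand bears on what lies behind it.

With a single replacement, the compounds shown cannot separate the smaller ring from the presence of the oxygen, so a comparison with thiophene-2-yl or pyrrol-2-yl at the same carbon would be needed to tell which of these goes with the step. From the compounds shown here alone, it also remains open how a group of a different kind at this carbon, such as an amine or a carboxylic acid, would behave, and whether the same swap has a similar effect on the other compounds.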